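This account rests on a few compounds, and the source may have more. Where it says the series, first, only, none or still open, it means among the compounds named here.

Working notes on the series.

Going by the values given here, compound 3 `Cn1cncc1C(O)(c1ccc(Cl)cc1)c1cc2cc([N+](=O)[O-])cc(-c3ccccc3)c2o1` stands at the top of the three numbers so far in a functional assay on QG-56 cells (Homo sapiens) for antiproliferative activity (a lower number here means a stronger inhibitor, a higher number a weaker inhibitor), where compound 3 gives 1890 nM. Compound 1 `Cn1cncc1C(O)(c1ccc(Cl)cc1)c1cc2cc(C(=O)NN3CCOCC3)cc(-c3ccccc3)c2o1` gives 73.6 nM in this assay, and compound 2 `COc1ccc(-c2cc([N+](=O)[O-])cc3cc(C(O)(c4ccc(C#N)cc4)c4cncn4C)oc23)cc1` gives 36 nM. Among the compounds with values here, the only step between measured compounds that differ in one place is a 26-fold higher number from compound 1 to compound 3 (1.41 log units; beyond the scatter), a change on the shared core and not on the six-membered aromatic ring of carbon only. Within the data shown here, compounds 2 and 3 differ in more than one place, so their two values show only that compound 2 sits lower.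

Compound 4 `Cn1cncc1C(O)(c1ccc(C(=O)OC(C)(C)C)cc1)c1cc2cc([N+](=O)[O-])cc(-c3ccccc3)c2o1` differs from compound 3 as follows: tert-butoxycarbonyl in place of chloro on an aromatic carbon. Among the measured compounds shown here, no measured step touches this ring; the step from compound 1 to compound 3 concerns another place, and the chloro-to-nitrile difference between compounds 1 and 2 is confounded by two further changes. With nothing in the series bearing directly on the change, no step beyond the scatter is expected for a 1.3-fold lower number from compound 3 to compound 4 (0.10 log units; within the scatter), and the range is left broad. Compound 4 is accordingly estimated at 1500 nM, between 350 nM and 6500 nM.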

Compound 4, half-maximal inhibitory concentration: 6250 nM
Estimate against measurement, compound 4: 4.2-fold (0.62 log units) below; low and high end bracket the measured number.
By their numbers in this assay, from the lowest: compound 2; then compound 1; then compound 3; then compound 4.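

The position on the six-membered aromatic ring of carbon only, para to a large group, now has its first direct reading in this assay: tert-butoxycarbonyl in place of chloro gives a 3.3-fold higher number from compound 3 to compound 4 (0.52 log units; beyond the scatter) and so lies beyond the scatter. This position therefore responds to substitution, although this modest step is smaller than a 26-fold higher number from compound 1 to compound 3 (1.41 log units; beyond the scatter) at the other place on the shared core. Nothing measured bears on why the number rises with this change.

This single pair cannot separate the added heavy atoms of tert-butoxycarbonyl from its carbonyl or its hydrogen-bond acceptors, nor show whether the step belongs to the ester as such. A carboxylic acid, a methyl ester or an amine at the same position would test this, and the same change on the core of compound 1, with (morpholin-4-yl)carbamoyl in place of nitro, would show whether the step carries over.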